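Notes on the alkylidene series: furan to propyl

This account rests on a few compounds, and the source may have more. Where it says the series, first, only, none or still open, it means among the compounds named here.

Compound 3 `CC(=O)OC[C@H]1O[C@@H](n2cc(CN3C(=O)/C(=C\c4ccco4)c4ccccc43)nn2)[C@H](OC(C)=O)[C@@H](OC(C)=O)[C@@H]1OC(C)=O` stands second highest of the three numbers in a functional assay on A549 cells (Homo sapiens) for cytotoxicity, read by sulforhodamine B assay, with a stated time of 48 h; a higher number here means a weaker inhibitor, a lower number a stronger inhibitor; in this assay compound 3 gives 41100 nM. Compound 1 `CC(=O)OC[C@H]1O[C@@H](n2cc(CN3C(=O)/C(=C\c4ccc5ccccc5c4)c4ccccc43)nn2)[C@H](OC(C)=O)[C@@H](OC(C)=O)[C@@H]1OC(C)=O` gives 62200 nM, and compound 2 `CC(=O)OC[C@H]1O[C@@H](n2cc(CN3C(=O)/C(=C\c4cccs4)c4ccccc43)nn2)[C@H](OC(C)=O)[C@@H](OC(C)=O)[C@@H]1OC(C)=O` gives 16100 nM. The measured steps are a 1.5-fold lower number from compound 1 to compound 3 (0.18 log units; within the scatter), a 2.6-fold higher number from compound 2 to compound 3 (0.41 log units; beyond the scatter) and a 3.9-fold lower number from compound 1 to compound 2 (0.59 log units; beyond the scatter). Compound 4 `CCC/C=C1\C(=O)N(Cc2cn([C@@H]3O[C@H](COC(C)=O)[C@@H](OC(C)=O)[C@H](OC(C)=O)[C@H]3OC(C)=O)nn2)c2ccccc21` differs from compound 3 by propyl in place of furan-2-yl on a double-bonded chain carbon bound to a double-bonded ring carbon. Going by the values given here, every measured step alters the group at this same place, but each swaps one aromatic ring for another; none replaces the ring with a chain, so no step bears directly on the present change. The ring swaps produced at most modest movement, and the three values lie close together, so a large shift is not anticipated. The expected outcome is a step of a 1.6-fold higher number from compound 3 to compound 4 (0.20 log units; within the scatter) in this assay, toward a higher number or none beyond the scatter. The estimated value of compound 4 in this assay is 65000 nM, with a range from 20000 nM to 200000 nM.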

Compound 4, half-maximal inhibitory concentration: 40400 nM
Estimate against measurement, compound 4: 1.6-fold (0.21 log units) above; the measured number falls inside the stated range.
By their numbers in this assay, from the lowest: compound 2; then compounds 4, 3 and 1 (each within the scatter of the next).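

In this assay, a ring at this place, on a double-bonded chain carbon bound to a double-bonded ring carbon, is not required to match the furan-2-yl and naphthalen-2-yl compounds: propyl, which has no ring, gives no step beyond the scatter against either (a 1.0-fold lower number from compound 3 to compound 4 (0.01 log units; within the scatter); a 1.5-fold lower number from compound 1 to compound 4 (0.19 log units; within the scatter)). The thiophen-2-yl compound alone stands apart from the propyl compound (a 2.5-fold higher number from compound 2 to compound 4 (0.40 log units; beyond the scatter)), so among these four compounds, ring against chain does not separate the values, and compound 2 goes against any picture of a flat position. No measurement available here explains these values.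

From the compounds shown here alone, whether a longer chain, or a propyl chain ending in an amine or a carboxylic acid, would stay with compound 4 or move toward compound 2 remains open.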